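The source may hold more compounds than are shown below. What is called first, only, known or untested is meant among the compounds shown, and "the series" means these compounds.

Compound 1 `O=C(COc1ccc(/C=C2\SC(=O)NC2=O)cc1)Nc1ccc([N+](=O)[O-])cc1`: in a functional assay on K562 cells (Homo sapiens) for inhibition (on this read-out lower numbers stand for stronger inhibition of growth and higher numbers for weaker inhibition of growth), compound 1 gives 29500 nM.
Compound 2 `O=C(COc1ccc(/C=C2\SC(=O)NC2=O)cc1)Nc1ccccc1`: in this assay compound 2 gives 17600 nM.
Compound 3 `O=C(COc1ccc(/C=C2\SC(=O)NC2=O)cc1)Nc1ccc(F)cc1F`: in this assay compound 3 gives 900 nM.

Compound 2 stands second highest of these three numbers. Its nearest neighbour lies within the scatter: a 1.7-fold lower number from compound 1 to compound 2 (0.22 log units; within the scatter). Its furthest neighbour lies well beyond it: a 20-fold lower number from compound 2 to compound 3 (1.29 log units; beyond the scatter).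

Compound 4 `O=C(COc1ccc(/C=C2\SC(=O)NC2=O)cc1)Nc1c(F)cc(Br)cc1F` has not yet been measured. It differs from compound 2 by 4-bromo-2,6-difluorophenyl in place of phenyl on an amide-type nitrogen. The measured step that bears most directly on this change is a 20-fold lower number from compound 2 to compound 3 (1.29 log units; beyond the scatter), where a fluorinated phenyl likewise replaced the plain phenyl on the same amide-type nitrogen; a related step is a 33-fold lower number from compound 1 to compound 3 (1.52 log units; beyond the scatter). Both were large and in the same direction. For the measured compounds named here, compound 4 also carries fluorine on that phenyl, together with a bromine, for which no measured step exists here. A large step downward is therefore expected: an 8.8-fold lower number from compound 2 to compound 4 (0.94 log units; beyond the scatter). Compound 4 is expected to give 2000 nM, within a range from 500 nM to 8000 nM.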

Compound 4, concentration for 50% growth inhibition: 23100 nM
Compound 4: middle estimate off by 12-fold (1.06 log units), on the low side; measured number above the stated range.
By their numbers in this assay, from the lowest: compound 3; then compounds 2, 4 and 1 (each within the scatter of the next).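

In this assay, fluorine on the phenyl at the amide-type nitrogen does not by itself bring the gain seen for compound 3: with 4-bromo-2,6-difluorophenyl in that place, a 1.3-fold higher number from compound 2 to compound 4 (0.12 log units; within the scatter) shows no separation from the plain phenyl, and a 1.3-fold lower number from compound 1 to compound 4 (0.11 log units; within the scatter) shows none from the 4-nitrophenyl compound either. For the compounds shown here, the one large step falls between two fluorinated groups, a 26-fold higher number from compound 3 to compound 4 (1.41 log units; beyond the scatter), which ties the gain to 2,4-difluorophenyl in particular and not to the presence of fluorine on this ring in general. No measurement offered here accounts for that difference.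

The compounds shown leave open whether the bromine or the placing of the fluorines separates compound 4 from compound 3, since the two groups differ in both at once. They also leave open how a 4-chlorophenyl or a 4-aminophenyl group would behave on this nitrogen.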